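Changing the Terminal Amine on the Side Chain of Compound 1

The source may hold more compounds than are shown below. What is called first, only, known or untested is meant among the compounds shown, and "the series" means these compounds.

Compound 1 `COc1cc2c(Oc3c(F)cc(NC(=O)NN4C(=O)CSC4c4c(F)cccc4F)cc3F)ccnc2cc1OCCCN1CCCC1` was tested in a functional assay on A549 cells (Homo sapiens) for antiproliferative activity, read by MTT assay, with a stated time of 72 h (a lower number here means a stronger inhibitor, a higher number a weaker inhibitor), and gave 560 nM. Among the measured compounds shown here, its only measured neighbour, compound 2 `COc1cc2c(Oc3c(F)cc(NC(=O)NN4C(=O)C(C)SC4c4c(F)cccc4F)cc3F)ccnc2cc1OCCCN1CCCC1`, carries a methyl in place of hydrogen on a saturated ring carbon and gave 830 nM in this assay; the step of a 1.5-fold higher number from compound 1 to compound 2 (0.17 log units; within the scatter) is within the scatter, so the two numbers cannot be told apart.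

Compound 3 `CCN1CCN(CCCOc2cc3nccc(Oc4c(F)cc(NC(=O)NN5C(=O)CSC5c5c(F)cccc5F)cc4F)c3cc2OC)CC1` is unmeasured. It differs from compound 1 by 4-ethylpiperazin-1-yl in place of pyrrolidin-1-yl on a saturated chain carbon, three bonds along the chain from an oxygen on an aromatic ring, so the shared core and the urea-linked part are untouched and only the basic end of the three-carbon chain is exchanged. For the measured compounds named here, no measured step touches this chain: the single step that is known, from compound 1 to compound 2, concerns the saturated ring far from the chain and was within the scatter, and it gives no guide to the size or direction of the present change.

With nothing pointing either way, compound 3 is expected to stay close to compound 1, the estimated step being no change at the digits printed from compound 1 to compound 3 (within the scatter). The estimate for compound 3 in this assay is 560 nM, with a range from 220 nM to 1400 nM.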

Compound 3, half-maximal inhibitory concentration: 350 nM
Estimate against measurement, compound 3: 1.6-fold (0.20 log units) above; the measured number falls inside the stated range.
By their numbers in this assay, from the lowest: compounds 3, 1 and 2 (each within the scatter of the next, the first and the last beyond it).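

In this assay, exchanging pyrrolidin-1-yl for 4-ethylpiperazin-1-yl at the end of the three-carbon chain gives a 1.6-fold lower number from compound 1 to compound 3 (0.20 log units; within the scatter), so the two compounds cannot be told apart. Among the compounds shown here, this is the first reading at this position, and it shows that the end of the chain can go from a five-membered ring of 5 heavy atoms to a six-membered ring of 8 heavy atoms, with a second nitrogen, without a step beyond the scatter. Nothing measured here offers an explanation of why the two numbers lie so close.

As far as these compounds go, one exchange cannot show how much room this position allows, so it remains open whether a morpholin-4-yl ring, an open-chain dimethylamino group or a carboxylic acid in the same place would also stay within the scatter of compound 1. Also open, from the compounds shown here alone, is whether a longer chain between the oxygen on the aromatic ring and the 4-ethylpiperazin-1-yl group would leave the number as it stands or move it beyond the scatter.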